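Methoxy to hydroxy on a urea-bearing pyrazole series

The source may report more compounds than this note shows. Statements on the series, on what has been measured and on what is new or still open speak of the compounds shown alone.

Measured compounds:
compound 1, `O=C(Nc1cccc(-n2cc(-c3ccncc3)c(-c3ccc(Cl)c(O)c3)n2)c1)Nc1cccc(C(F)(F)F)c1`, > 32500 nM
compound 2, `COc1cc(-c2nn(-c3cccc(NC(=O)Nc4ccc(Cl)c(C(F)(F)F)c4)c3)cc2-c2ccncc2)ccc1Cl`, > 32500 nM

Both were tested in a functional assay on K562 cells (Homo sapiens) for inhibition, read by sulforhodamine B assay, with a stated time of 48 h; on this read-out lower numbers stand for higher toxicity in this test and higher numbers for lower toxicity in this test. For compound 1 the value of > 32500 nM is a limit of the assay, not a number. For compound 2 the value of > 32500 nM is likewise a limit. Compound 2 therefore stands at the limit of > 32500 nM in this assay, at which 2 of the 2 values shown sit, so no ordering between the two compounds can be read off.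

The next compound, compound 3, `O=C(Nc1cccc(-n2cc(-c3ccncc3)c(-c3ccc(Cl)c(O)c3)n2)c1)Nc1ccc(Cl)c(C(F)(F)F)c1`, differs from compound 2 by hydrogen in place of methyl on an oxygen on an aromatic ring, turning 4-chloro-3-methoxyphenyl into 4-chloro-3-hydroxyphenyl. Among the compounds with values here, no step between measured compounds is available to size this change. Compound 1 already carries the 4-chloro-3-hydroxyphenyl group and sits at the limit of > 32500 nM in this assay, at which 2 of the 2 values shown sit. The step that the limit leaves unreadable from compound 2 to compound 3 is expected to be none beyond the scatter. Compound 3 is expected to give about 50000 nM, within 20000 nM to 200000 nM, most likely again only as a limit.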

Compound 3, concentration lethal to 50% of the cells: > 32500 nM
Compound 3 gave a limit, no number; the forecaster's own chance of this, stated with the estimate: 85%; the middle value is on the limit's open side.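

No new step can be read among compound 1, compound 2 and compound 3, as all three stop at one limit and give no number: the limit of > 32500 nM in this assay, at which 3 of the 3 values shown sit.

From the compounds shown here alone, whether methoxy to hydroxy, or chloro in place of hydrogen, changes the result in this assay stays open, as does the true value of each compound.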